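A few compounds are considered here, and "the series" means these few. Any claim that something is new, unique, unknown or untested is made for them only; others in the source may bear on it.

Measured in a functional assay with Oryctolagus cuniculus as the target; a higher number here means a weaker inhibitor, a lower number a stronger inhibitor:
- Compound 1 `COc1ccc(-c2nc(/N=C(\N)N3CCOCC3)sc2-c2ccc(OC)cc2)cc1`: < 1000 nM, a limit
- Compound 2 `COc1ccc(-c2nc(CNC(=O)c3cccnc3)sc2-c2ccc(OC)cc2)cc1`: 25 nM
- Compound 3 `COc1ccc(-c2nc(CNC(=O)CSC)sc2-c2ccc(OC)cc2)cc1`: < 100 nM, a limit

Compound 3 stands at a limit and not at an exact number, as the limit of < 100 nM in this assay, at which 1 of the 3 values shown sits, shows. Compound 4 `COc1ccc(-c2nc(C(=O)N(C)C)sc2-c2ccc(OC)cc2)cc1` has not yet been measured. It keeps the core of compound 3 and changes one group: dimethylcarbamoyl in place of ((((methylsulfanyl)methyl)carbonyl)amino)methyl on an aromatic carbon.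

Going by the values given here, three measured steps bear on this change. Two replace the whole group on the aromatic carbon, a step that the limit leaves unreadable from compound 1 to compound 2 and a step that the two limits leave unreadable from compound 1 to compound 3. The third alters only the end of the chain, a step that the limit leaves unreadable from compound 2 to compound 3. None of them has a size that can be read, so they point in no direction.

Among the compounds with values here, the only exact value is that of compound 2, 25 nM, so the expectation leans on it and stays wide. The expected change is a step that the limit leaves unreadable from compound 3 to compound 4, with no clear direction expected. For compound 4 the estimated value is 80 nM, with an expected range of 10 nM to 600 nM.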

Compound 4, half-maximal inhibitory concentration: < 100 nM
Compound 4 ended at the assay's limit; the forecaster's own chance of this, stated with the estimate: 35%; the middle value does not contradict the limit.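

In this assay compound 4 gives < 100 nM, which is a limit and not a number, so its steps to compound 1, compound 2 and compound 3 cannot be read. The compounds shown leave open how dimethylcarbamoyl truly compares with the group it replaces in compound 3 or compound 2.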